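Compound 3 to compound 4: a 3-carboxyazetidin-1-yl swap

A few compounds are considered here, and "the series" means these few. Any claim that something is new, unique, unknown or untested is made for them only; others in the source may bear on it.

Measured in a functional assay on MC-38 cells (Mus musculus) for antiproliferative activity, read by CCK-8 assay, with a stated time of 48 h; a lower number here means a stronger inhibitor, a higher number a weaker inhibitor:
- Compound 1 `COc1ccc(/C=C\c2cc(OC)c(OC)c(OC)c2)cc1OCc1ccc(C=O)cc1`: 900 nM.
- Compound 2 `COc1ccc(/C=C\c2cc(OC)c(OC)c(OC)c2)cc1OCc1ccc(CN2CCCCC2C(=O)O)cc1`: 5400 nM.
- Compound 3 `COc1ccc(/C=C\c2cc(OC)c(OC)c(OC)c2)cc1OCc1ccc(CN[C@H](C(=O)O)[C@H](C)O)cc1`: > 10000 nM, a limit and not a number.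

Compound 3 is known only by the limit of > 10000 nM in this assay, at which 1 of the 3 values shown sits. Compound 4 `COc1ccc(/C=C\c2cc(OC)c(OC)c(OC)c2)cc1OCc1ccc(CN2CC(C(=O)O)C2)cc1` departs from it by one change: 3-carboxyazetidin-1-yl in place of (1-carboxy-2-hydroxypropyl)amino on a saturated chain carbon bound to an aromatic carbon. The open (1-carboxy-2-hydroxypropyl)amino gives way to the ring-bearing 3-carboxyazetidin-1-yl, on a saturated chain carbon bound to an aromatic carbon.

Among the compounds with values here, three measured steps bear on this. The first is a 6.0-fold higher number from compound 1 to compound 2 (0.78 log units; beyond the scatter). The second is an at least 11-fold higher number from compound 1 to compound 3 (1.04 log units; beyond the scatter). The third, an at least 1.8-fold higher number from compound 2 to compound 3 (0.26 log units; that floor lies within the scatter), has a floor that does not clear the scatter. Compound 2 also carries a ring with a carboxy group, so it is the nearest guide, and compound 2 gives 5400 nM. A modest move to a lower number is therefore expected, and it may prove small: an at least 1.6-fold lower number from compound 3 to compound 4 (0.22 log units; that floor lies within the scatter). For compound 4 the estimated value in this assay is 6000 nM, with an expected range from 2000 nM to 15000 nM.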

Compound 4, half-maximal inhibitory concentration: > 10000 nM
Compound 4 ended at the assay's limit; the forecaster's own chance of this, stated with the estimate: 30%; at least 1.6-fold (0.22 log units) between middle value and limit.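

In this assay, the ring-bearing (3-carboxyazetidin-1-yl)methyl in place of formyl gives an at least 11-fold higher number from compound 1 to compound 4 (1.04 log units; beyond the scatter), so a second carboxy-bearing ring joins the open-chain carboxy group in sitting well away from compound 1. Against the other ring, the floor of an at least 1.8-fold higher number from compound 2 to compound 4 (0.26 log units; that floor lies within the scatter) does not separate 3-carboxyazetidin-1-yl from 2-carboxypiperidin-1-yl, so carrying a ring did not by itself place compound 4 on a readable value as it did compound 2. The step from compound 3 to compound 4 cannot be read, as each compound is known only by a limit, and this change therefore shows no measurable gain in this position: the limit of > 10000 nM in this assay, at which 2 of the 4 values shown sit.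

Still open, as far as these compounds go, is whether an amine without the carboxylic acid, or a methyl ester in its place, on this saturated chain carbon would come back towards compound 1 at 900 nM. Also open, from the compounds shown here alone, is how far beyond the limit compound 3 and compound 4 lie, and whether they differ at all.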